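The compounds below may be only part of what the source reports. "The series", "measured", "known", "first", "only" and "open" are said of these compounds alone.

Three compounds sharing one core were tested in an ADME assay on Vero cells (Chlorocebus sabaeus) for cytotoxicity, read by MTT assay, with a stated time of 48 h; a higher number here means a weaker inhibitor, a lower number a stronger inhibitor. Compound 1 `CCCC(=O)OC1CCC(CN2CCN(c3cc(=O)c4cc(C(F)(F)F)cc([N+](=O)[O-])c4s3)CC2)CC1` carries a propyl on a carbonyl carbon, and in this assay compound 1 gives only a limit, > 64 ug/mL. Compound 2 `Cc1ccc(C(=O)OC2CCC(CN3CCN(c4cc(=O)c5cc(C(F)(F)F)cc([N+](=O)[O-])c5s4)CC3)CC2)cc1` carries a 4-methylphenyl in that place, and compound 2 also gives only a limit, > 64 ug/mL. Compound 3 `CC(=O)OC1CCC(CN2CCN(c3cc(=O)c4cc(C(F)(F)F)cc([N+](=O)[O-])c4s3)CC2)CC1` carries a methyl there, and compound 3 likewise gives only a limit, > 64 ug/mL. The steps a step that the two limits leave unreadable from compound 1 to compound 2, a step that the two limits leave unreadable from compound 1 to compound 3 and a step that the two limits leave unreadable from compound 2 to compound 3 cannot be sized because of the limit of > 64 ug/mL in this assay, at which 3 of the 3 values shown sit. Compound 4 `O=C(OC1CCC(CN2CCN(c3cc(=O)c4cc(C(F)(F)F)cc([N+](=O)[O-])c4s3)CC2)CC1)c1ccc2ccccc2c1` has not yet been measured and differs from compound 3 by naphthalen-2-yl in place of methyl on a carbonyl carbon. With every measured step unreadable, no movement beyond the scatter is expected. Compound 4 is therefore estimated at 64 ug/mL, between 32 ug/mL and 128 ug/mL, an expected step of a number no higher from compound 3 to compound 4 (the limit leaves the size open).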

Compound 4, half-maximal inhibitory concentration: > 64 ug/mL
Compound 4: a limit, no number; the forecaster's own chance of this, stated with the estimate: 70%; the middle value sits exactly at the limit.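

Compound 4, like compound 1, compound 2 and compound 3, gives only a limit, so no step to compound 4 can be read, because all four stop at the same point: the limit of > 64 ug/mL in this assay, at which 4 of the 4 values shown sit.

The compounds shown leave open whether changing the group on the carbonyl carbon alters the result in this assay at all.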